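Fluoro in Place of Hydrogen on Compound 1

The source may report more compounds than this note shows. Statements on the series, on what has been measured and on what is new or still open speak of the compounds shown alone.

Going by the values given here, in a functional assay on the whole organism with Mus musculus as the target, in the maximal electroshock model (on this read-out lower numbers stand for an effect already at smaller amounts and higher numbers for an effect only at larger amounts of compound), compound 1 (`OC1CCN(c2ccc(-c3ccccc3)nn2)CC1`) gives 86 mg/kg, the higher of the two numbers measured so far, and compound 2 (`OC1CCN(c2ccc(-c3ccc(Cl)cc3)nn2)CC1`) gives 29 mg/kg. Compound 3 (`OC1CCN(c2ccc(-c3ccccc3F)nn2)CC1`) carries fluoro in place of hydrogen on an aromatic carbon, ortho to a large group (fluoro in place of hydrogen on an aromatic carbon). Among the compounds with values here, the only measured step that bears on this is modest, a 3.0-fold lower number from compound 1 to compound 2 (0.47 log units; beyond the scatter), and it brings chloro rather than fluoro. A smaller step toward a lower number is therefore expected, one that may stay within the scatter. The expected change is a 1.6-fold lower number from compound 1 to compound 3 (0.19 log units; within the scatter). Compound 3 is estimated at 55 mg/kg, within a range of 22 mg/kg to 130 mg/kg.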

Compound 3, dose for half-maximal effect: 115 mg/kg
The estimate for compound 3 lay 2.1-fold (0.32 log units) below the measured number, and the stated range covers the measured number.
By their numbers in this assay, from the lowest: compound 2; then compounds 1 and 3 (each within the scatter of the next).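

In this assay, fluoro in place of hydrogen on an aromatic carbon, ortho to a large group, gives a 1.3-fold higher number from compound 1 to compound 3 (0.13 log units; within the scatter) and so leaves the number within the scatter, whereas the chloro step gives a 3.0-fold lower number from compound 1 to compound 2 (0.47 log units; beyond the scatter) and lies beyond it. Halogen in place of hydrogen on this ring therefore does not always move the number beyond the scatter, although the halogen and its place both differ between these two steps. Nothing measured here explains the result. On these data alone, whether chloro, methoxy or an amine at this same place would move the number remains open, and so does whether fluoro would match chloro in the place chloro holds in compound 2.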